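This account rests on a few compounds, and the source may have more. Where it says the series, first, only, none or still open, it means among the compounds named here.

Compound 2, `CC(=O)NCCN(C)c1cccc(OCCCCCCNC(=O)Oc2cccc(-c3ccccc3)c2)c1`, and compound 1, `CC(=O)NCCN(C)c1cccc(OCCCCNC(=O)Oc2cccc(-c3ccccc3)c2)c1`, share the same core and the same end group, and differ only in the length of the chain that links them. In an assay on cells for displacement of a labelled ligand from melatonin receptor type 1B (Homo sapiens), using the Cheng-Prusoff equation, with a stated time of 90 min (a lower number here means a stronger inhibitor, a higher number a weaker inhibitor), compound 2 gives 33.1 nM and compound 1 gives 44.7 nM; these two values lie within the usual scatter of each other, so neither compound stands apart from the other. Compound 3, `CC(=O)NCCN(C)c1cccc(OCCCCCCNC(=O)Oc2cccc(-c3cccc(O)c3)c2)c1`, keeps the longer chain of compound 2 and brings a single change: hydroxy in place of hydrogen on an aromatic carbon. Going by the values given here, no pair of measured compounds shows a change of this kind, so its effect cannot be read off the data and has to be estimated. The expectation for a 1.1-fold lower number from compound 2 to compound 3 (0.04 log units; within the scatter) is a step of no more than the scatter, in either direction. On that basis compound 3 is estimated at 30 nM, with a range from 10 nM to 100 nM.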

Compound 3, inhibition constant: 26.9 nM
Compound 3: middle estimate off by 1.1-fold (0.05 log units), on the high side; measured number inside the range.
By their numbers in this assay, from the lowest: compounds 3, 2 and 1 (each within the scatter of the next).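

In this assay, placing hydroxy on an aromatic carbon, meta to a large group, gives a 1.2-fold lower number from compound 2 to compound 3 (0.09 log units; within the scatter), so turning phenyl into 3-hydroxyphenyl leaves the number where repeated measurements could place it anyway. Compounds 1 and 2 differ only in chain length and say nothing about this outer ring; compound 3 gives the first reading there, showing that the ring can carry hydroxy, with its hydrogen-bond donor and acceptor, without a step beyond the scatter. No measurement is available that explains this result.

As far as these compounds go, whether a methoxy group, a fluorine atom or an amine at the same place would behave like hydroxy remains open. So does whether hydroxy on another carbon of this ring, or on the shorter chain of compound 1, would give a similar step.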